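The source may report more compounds than this note shows. Statements on the series, on what has been measured and on what is new or still open speak of the compounds shown alone.

Measured so far:
- compound 1 `O=C1COc2ccc(-c3cccc(NS(=O)(=O)c4ccc(F)cc4)c3)cc2N1`: 20100 nM
- compound 2 `COc1ncc(-c2ccc3c(c2)N(c2ccc(F)cc2)C(=O)CO3)cc1NS(=O)(=O)c1ccc(F)cc1`: > 40000 nM (a limit)
- compound 3 `COc1ccc(N2C(=O)COc3ccc(-c4cnc5ccccc5c4)cc32)cc1`: > 40000 nM (a limit)

Among the compounds with values here, in a functional assay on A-375 cells (Homo sapiens) for antiproliferative activity, read by MTT assay, with a stated time of 72 h (on this read-out lower numbers stand for stronger inhibition and higher numbers for weaker inhibition), compound 1 gives 20100 nM, and it is the only compound of the three with an actual number. The other two values are limits and not numbers.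

Compound 4 `O=C1COc2ccc(-c3cccc(NS(=O)(=O)c4ccc(F)cc4)c3)cc2N1C1CCCCC1` is the next to be read. It has cyclohexyl in place of hydrogen on an amide-type nitrogen in a ring of the core of compound 1: cyclohexyl in place of hydrogen on an amide-type nitrogen in a ring.

Within the data shown here, compound 2 and compound 3 also carry a ring on that nitrogen, but they differ from compound 1 elsewhere too, so no measured step isolates this change. Neither gives a number: they stand at the limit of > 40000 nM in this assay, at which 2 of the 3 values shown sit. That offers no hint of a gain, and a slight loss would not surprise. The expected 1.1-fold higher number from compound 1 to compound 4 (0.04 log units; within the scatter) is small, with no clear move beyond the scatter, and a reading at the limit remains possible. For compound 4 the estimate is 22000 nM, with an expected range of 8000 nM to 40000 nM.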

Compound 4, half-maximal inhibitory concentration: 23800 nM
For compound 4 the middle estimate is 1.1-fold (0.03 log units) below the measured one; the measured number falls inside the stated range.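

In this assay, the ring amide nitrogen now has its first isolated step: cyclohexyl in place of the amide hydrogen gives a 1.2-fold higher number from compound 1 to compound 4 (0.07 log units; within the scatter). Compound 2 and compound 3 also carry a ring on that nitrogen but differ elsewhere too, and each stands at a limit, not a number: the limit of > 40000 nM in this assay, at which 2 of the 4 values shown sit. Cyclohexyl on this nitrogen does not by itself take the series to that limit, and losing the amide hydrogen brings no change beyond the scatter, with no gain in inhibition.

From the compounds shown here alone, whether any group on this nitrogen can move the value beyond the scatter remains open. Methyl, or a chain ending in an amine or a carboxylic acid, has no reading among the compounds shown.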